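The source may report more compounds than this note shows. Statements on the series, on what has been measured and on what is new or still open speak of the compounds shown alone.

Measured in an ADME assay on HeLa cells (Homo sapiens) for cytotoxicity, read by resazurin assay, with a stated time of 2 days; on this read-out higher numbers stand for weaker inhibition and lower numbers for stronger inhibition:

- Compound 1 `CC(=O)OC(c1ccc(C)cc1)C(OC(C)=O)c1ncc([N+](=O)[O-])n1C` gives > 100000 nM
- Compound 2 `Cn1c([N+](=O)[O-])cnc1CCc1ccccc1` gives > 100000 nM
- Compound 3 `Cc1ccc(CCc2ncc([N+](=O)[O-])n2C)cc1` gives > 100000 nM

Compound 3 stands at > 100000 nM, which is a limit of the assay and not a number. The other two compounds also give only limits, so the limit of > 100000 nM in this assay, at which 3 of the 3 values shown sit, describes the whole set, and none of the three can be ranked against another.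

Compound 4 `Cn1c([N+](=O)[O-])cnc1CCc1ccc(Br)cc1` carries bromo in place of methyl on an aromatic carbon, para to a large group (bromo in place of methyl on an aromatic carbon). Among the measured compounds shown here, the one measured step that bears on this change is a step that the two limits leave unreadable from compound 2 to compound 3, which puts methyl in place of hydrogen on an aromatic carbon. That step offers no size to carry over. No change beyond the usual scatter is therefore expected in this assay, and no direction can be named. The expected step is a number no higher from compound 3 to compound 4 (the limit leaves the size open). The assay will most likely report only a limit again. For compound 4 the estimated value is 100000 nM, with an expected range from 40000 nM to 150000 nM.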

Compound 4, half-maximal inhibitory concentration: 97700 nM
Compound 4: middle estimate off by 1.0-fold (0.01 log units), on the high side; the measured number falls inside the stated range.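

In this assay, among the compounds shown here, compound 4 gives 97700 nM, the only value in this set that is a number and not a limit, so a substituent on the six-membered aromatic ring, para to a large group, now has a measured reading. Bromo in place of methyl gives an at least 1.0-fold lower number from compound 3 to compound 4 (0.01 log units; that floor lies within the scatter), and bromo in place of hydrogen gives an at least 1.0-fold lower number from compound 2 to compound 4 (0.01 log units; that floor lies within the scatter), so neither step shows a real change. The other compounds give no number against which compound 4 could be placed: the limit of > 100000 nM in this assay, at which 3 of the 4 values shown sit.

The compounds shown leave open whether an amine or a carboxylic acid at this same place would bring the number beyond the usual scatter of compound 4. They also leave open whether a longer chain in the shared core would do so.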